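From a Piperidine to a Urea-Bearing Pyrrolidine

This account rests on a few compounds, and the source may have more. Where it says the series, first, only, none or still open, it means among the compounds named here.

Compound 1 `CC(C)N(C)c1ccc2cc(NC(=O)CCc3ccc(C(F)(F)F)cc3)ccc2n1` gives 140 nM in a functional assay on HEK293 cells for activation of melanin-concentrating hormone receptor 1 (Rattus norvegicus), read by inositol phosphate accumulation; on this read-out lower numbers stand for an effect already at smaller amounts and higher numbers for an effect only at larger amounts of compound.
Compound 2 `O=C(CCc1ccc(C(F)(F)F)cc1)Nc1ccc2nc(N3CCCC3)ccc2c1` gives 320 nM; 320 nM (2 entries).
Compound 3 `O=C(CCc1ccc(C(F)(F)F)cc1)Nc1ccc2nc(N3CCCCC3)ccc2c1` gives 110 nM.

These three compounds share one core and differ only in the amine sitting on an aromatic carbon. Compound 3 holds the lowest of the two single numbers, with compound 1 nearest: a 1.3-fold lower number from compound 1 to compound 3 (0.10 log units; within the scatter), which lies within the scatter, so no order between the two can be claimed. Compound 2 has two entries rather than one number, and both lie higher than the value of compound 3.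

Compound 4 `CNC(=O)NC1CCN(c2ccc3cc(NC(=O)CCc4ccc(C(F)(F)F)cc4)ccc3n2)C1` carries the change (3-((methylcarbamoyl)amino)pyrrolidin-1-yl in place of piperidin-1-yl on an aromatic carbon). For the measured compounds named here, no measured step covers this exact change. Going by the values given here, the only recorded step, from compound 1 to compound 3, swaps one amine for another and stays within the scatter. Among the compounds with values here, the values of compound 2 and compound 3 show that a five-membered ring in place of a six-membered one went with a higher number, although no step is computed for that pair. The methylcarbamoyl-amino part on the five-membered ring is new, and nothing measured speaks to it. The expected step is a 2.0-fold higher number from compound 3 to compound 4 (0.30 log units; within the scatter), a modest rise in the number carrying wide uncertainty. The expected value for compound 4 in this assay is 220 nM, most likely between 50 nM and 900 nM.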

Compound 4, half-maximal effective concentration: 30 nM
The estimate for compound 4 lay 7.3-fold (0.87 log units) above the measured number; the measured number lies below the stated range.
By their numbers in this assay, from the lowest: compound 4; then compounds 3 and 1 (each within the scatter of the next).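

At this aromatic carbon next to the ring nitrogen, the simple amines of compound 1 and compound 3 stayed within the scatter of each other, but 3-((methylcarbamoyl)amino)pyrrolidin-1-yl moves the result beyond it in this assay: a 3.7-fold lower number from compound 3 to compound 4 (0.56 log units; beyond the scatter), and a 4.7-fold lower number from compound 1 to compound 4 (0.67 log units; beyond the scatter). The position therefore accepts a larger group with hydrogen-bond donors, which piperidin-1-yl lacks, and the number still falls. The five-membered ring alone does not go with this low number, since compound 2, with the same ring and no methylcarbamoyl-amino group, gives 320 nM; 320 nM (2 entries), while compound 4 gives 30 nM; no measurement at hand explains the gain.

As far as these compounds go, it remains open whether the methylcarbamoyl-amino group would give a similar result on a six-membered piperidine ring, which would separate the effect of the group from that of the ring that carries it. From the compounds shown here alone, it is also open which part of the group matters, a question that a plain amine, an acetamide or a carboxylic acid in its place on the five-membered ring could address.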